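Substituent at the fused ring: bromo, methyl, hydrogen

The source may report more compounds than this note shows. Statements on the series, on what has been measured and on what is new or still open speak of the compounds shown alone.

Measured so far in a functional assay on NCI-H460 cells (Homo sapiens) for inhibition, read by MTT assay, with a stated time of 72 h; a higher number here means a weaker inhibitor, a lower number a stronger inhibitor:
- compound 1 `CCN(CC)CCCn1c(=O)c(=Cc2ccccc2O)s/c1=C1\C(=O)Nc2ccc(Br)cc21`: 51700 nM
- compound 2 `CCN(CC)CCCn1c(=O)c(=Cc2ccccc2O)s/c1=C1\C(=O)Nc2ccc(C)cc21`: 11300 nM

Among the compounds with values here, compound 2 stands lowest of the two numbers in this assay; the only neighbour is compound 1, and the step of a 4.6-fold lower number from compound 1 to compound 2 (0.66 log units; beyond the scatter) separates them, a change that is beyond the scatter though modest in size.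

Compound 3 `CCN(CC)CCCn1c(=O)c(=Cc2ccccc2O)s/c1=C1\C(=O)Nc2ccccc21` is not yet measured. It differs from compound 2 in one place: hydrogen in place of methyl on an aromatic carbon. The position is the same aromatic carbon at which compound 1 carries bromo and compound 2 carries methyl.

Within the data shown here, only one measured step bears on this change, a 4.6-fold lower number from compound 1 to compound 2 (0.66 log units; beyond the scatter), and it concerns a different exchange at that carbon. It shows that this position is sensitive in this assay, but it gives no direction for loss of the methyl. With hydrogen at that carbon there is no measured comparison at all, so the expectation rests on compound 2 alone with a wide range. The step from compound 2 to compound 3 is estimated as a 1.3-fold higher number from compound 2 to compound 3 (0.12 log units; within the scatter), likely within the scatter. Compound 3 is expected at 15000 nM, with a range from 5000 nM to 45000 nM.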

Compound 3, half-maximal inhibitory concentration: > 200000 nM
Compound 3 gave a limit, no number (the forecaster's own chance of this, stated with the estimate: 10%); middle value at least 13-fold (1.12 log units) from the limit.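

In this assay, compound 3 stands at a limit and not at a number: the limit of > 200000 nM in this assay, at which 1 of the 3 values shown sits.

The steps to hydrogen run in the same direction from both substituted compounds, with an at least 17-fold higher number from compound 2 to compound 3 (1.24 log units; beyond the scatter) and an at least 3.8-fold higher number from compound 1 to compound 3 (0.58 log units; beyond the scatter), so compound 3 is the weakest of the three and both methyl and bromo lie on the stronger side of hydrogen, which the comparison of compound 1 with compound 2 alone could not show. At this aromatic carbon, the loss of a single heavy atom counts for more than the exchange of bromo for methyl, which is a 4.6-fold lower number from compound 1 to compound 2 (0.66 log units; beyond the scatter).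

Within the data shown here, both steps to compound 3 are open-ended, so their true size remains unknown, and with only three compounds no ranking of substituents at this carbon can be extended beyond hydrogen, bromo and methyl. On these data alone, whether a chloro, a methoxy or an ethyl group at the same carbon would fall closer to methyl or to bromo, or would improve on methyl, remains open, as does whether the same large step on losing the methyl would hold with a different chain on the shared core.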